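This account rests on a few compounds, and the source may have more. Where it says the series, first, only, none or still open, it means among the compounds named here.

Measured compounds:
compound 1 `O=C(/C=C/c1ccc(Oc2ncnc3ccc(Cl)cc23)cc1)/C=C/c1c(Cl)cccc1Cl` — in a functional assay on PC-3 cells (Homo sapiens) for inhibition, read by MTT assay, with a stated time of 72 h, tested at 10 uM (a lower number here means less inhibition of growth, a higher number more inhibition of growth at the concentration tested), compound 1 gives 67.5%
compound 2 `O=C(/C=C/c1ccc(Cl)c([N+](=O)[O-])c1)/C=C/c1ccccc1Oc1ncnc2ccc(Cl)cc12` — in this assay compound 2 gives 62.5%
compound 3 `O=C(/C=C/c1ccc(Oc2ncnc3ccc(Cl)cc23)cc1)/C=C/c1cccc(Cl)c1Cl` — in this assay compound 3 gives 67.4%

Among these three numbers compound 2 holds the lowest, but its gaps to compound 3 and to compound 1 both lie within the usual scatter, so the three compounds cannot be told apart on these data.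

Compound 4 `O=C(/C=C/c1ccccc1Oc1ncnc2ccc(Cl)cc12)/C=C/c1cccc(Cl)c1Cl` is derived from compound 2 by one change: 2,3-dichlorophenyl in place of 4-chloro-3-nitrophenyl on a double-bonded chain carbon bound to a double-bonded chain carbon. Among the compounds with values here, the only measured step, a number 0.1 percentage points lower from compound 1 to compound 3 (within the scatter), exchanged one dichlorophenyl pattern for another and left the read-out unchanged within the scatter. Within the data shown here, no measured step replaces a chloro-nitrophenyl with a dichlorophenyl, so that part of the change is untested here. Given that all three numbers sit close together and the one measured exchange of ring substituents moved nothing, the expected step of a number 2.5 percentage points higher from compound 2 to compound 4 (within the scatter) is none beyond the scatter. Compound 4 is therefore expected to give about 65% in this assay, with a range from 50% to 78%.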

Compound 4, percent growth inhibition at one concentration: 73.8%
Compound 4: the middle estimate sits 8.8 percentage points below what was measured; measured number inside the range.
By their numbers in this assay, from the lowest: compounds 2, 3, 1 and 4 (each within the scatter of the next, the first and the last beyond it).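

In this assay, putting 2,3-dichlorophenyl in place of 4-chloro-3-nitrophenyl on a double-bonded chain carbon bound to a double-bonded chain carbon gives a number 11.3 percentage points higher from compound 2 to compound 4 (beyond the scatter), so the group at this place can move the read-out beyond the scatter. The earlier exchange of one dichlorophenyl pattern for another, a number 0.1 percentage points lower from compound 1 to compound 3 (within the scatter), did not show this, as it stayed within the scatter. No measurement at hand accounts for the step.

The change removes the nitro group and adds a second chlorine at once, so the compounds shown do not tell which of the two goes with the higher number. On these data alone, it also remains open how a monochlorophenyl or an aminophenyl at this place would read in this assay.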